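The source may report more compounds than this note shows. Statements on the series, on what has been measured and on what is new or still open speak of the compounds shown alone.

Measured so far:
Compound 1, `CC(O)Cn1c([N+](=O)[O-])cnc1/C=C/c1ccc(Br)cc1`, gives 550 nM in an ADME assay on cells (Macrophage, Homo sapiens) for cytotoxicity, read by MTT assay, with a stated time of 24 h; on this read-out higher numbers stand for lower toxicity in this test and lower numbers for higher toxicity in this test.
Compound 2, `CC(O)Cn1c([N+](=O)[O-])cnc1/C=C/c1ccc([N+](=O)[O-])cc1`, gives 410 nM.
Compound 3, `CC(O)Cn1c([N+](=O)[O-])cnc1/C=C/c1ccccc1Br`, gives 490 nM.

All three share one core and differ only in the group on the benzene ring. From compound 1 to compound 2 the change is nitro in place of bromo on an aromatic carbon, and this gave a 1.3-fold lower number from compound 1 to compound 2 (0.13 log units; within the scatter). The two cores differ by 2-bromophenyl in place of 4-bromophenyl on a double-bonded chain carbon bound to a double-bonded chain carbon, which gave a 1.1-fold lower number from compound 1 to compound 3 (0.05 log units; within the scatter). Compound 4, `CC(O)Cn1c([N+](=O)[O-])cnc1/C=C/c1ccccc1[N+](=O)[O-]`, is not yet measured; it differs from compound 3 by nitro in place of bromo on an aromatic carbon. For the measured compounds named here, this is the same kind of change as the one from compound 1 to compound 2, but in compound 1 the place is para to a large group, while in compound 3 it is ortho to a large group. Since the earlier step was a 1.3-fold lower number from compound 1 to compound 2 (0.13 log units; within the scatter), a step of about a 1.2-fold lower number from compound 3 to compound 4 (0.09 log units; within the scatter) is expected from compound 3 to compound 4, resting on that single measured pair. Compound 4 is therefore estimated to give 400 nM, with a likely range from 200 nM to 800 nM.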

Compound 4, half-maximal cytotoxic concentration: 1090 nM
Compound 4: middle estimate off by 2.7-fold (0.44 log units), on the low side; measured number above the stated range.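

In this assay, nitro in place of bromo, ortho to a large group, gave a 2.2-fold higher number from compound 3 to compound 4 (0.35 log units; beyond the scatter), so compound 4 is less toxic in this test than compound 3. Set beside the earlier step, the same swap did not carry over from one core to the other as a fixed step: the same change on two cores in this assay, a 1.3-fold lower number (0.13 log units; within the scatter) from compound 1 to compound 2 and a 2.2-fold higher number (0.35 log units; beyond the scatter) from compound 3 to compound 4, 3.0-fold (0.47 log units) apart, beyond the scatter of two such steps. For the compounds shown here, this shows that, in this series, a step measured on one core can be a poor guide to the same swap on another, but with only two pairs it does not show why the steps differ or give a rule for any further core.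

The compounds shown leave open what other groups would do in place of the bromo or nitro, such as an amine, a carboxylic acid or a methoxy group. They also leave open whether the higher number of compound 4 is specific to nitro or would appear with other groups at that place.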